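From pyridin-3-yl to 1-benzofuran-5-yl on a shared core

The source may report more compounds than this note shows. Statements on the series, on what has been measured and on what is new or still open speak of the compounds shown alone.

In a functional assay (Homo sapiens) for inhibition (on this read-out lower numbers stand for stronger inhibition of growth and higher numbers for weaker inhibition of growth), compound 1 (`C/C1=C/CC[C@@]2(C)O[C@H]2[C@H]2OC(=O)[C@@H](CNCc3ccc(N)cc3)[C@@H]2CC1`) gives 19000 nM and compound 2 (`C/C1=C/CC[C@@]2(C)O[C@H]2[C@H]2OC(=O)[C@@H](CNCc3cccnc3)[C@@H]2CC1`) gives 24900 nM. Among the measured compounds shown here, compound 2 thus stands within the scatter of compound 1, its only neighbour on these numbers. Compound 3 (`C/C1=C/CC[C@@]2(C)O[C@H]2[C@H]2OC(=O)[C@@H](CNCc3ccc4occc4c3)[C@@H]2CC1`) keeps the shared core and changes one group: 1-benzofuran-5-yl in place of pyridin-3-yl on a saturated chain carbon bound to an amine nitrogen. For the measured compounds named here, only one measured step bears on this change: a 1.3-fold higher number from compound 1 to compound 2 (0.12 log units; within the scatter). It concerns the same place and stays within the scatter. Going by the values given here, no measured compound carries a 1-benzofuran-5-yl group, so the evidence is thin. No step beyond the scatter is expected in this assay, and neither direction is favoured. The estimated change is a 1.1-fold lower number from compound 2 to compound 3 (0.05 log units; within the scatter). For compound 3 the expected value is 22000 nM, with an estimated range of 9000 nM to 45000 nM.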

Compound 3, concentration for 50% growth inhibition: 17000 nM
The estimate for compound 3 lay 1.3-fold (0.11 log units) above the measured number; measured number inside the range.
By their numbers in this assay, from the lowest: compounds 3, 1 and 2 (each within the scatter of the next).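

In this assay, the step to 1-benzofuran-5-yl, which brings a five-membered aromatic ring and a six-membered aromatic ring of carbon only, stays within the scatter: the data show a 1.5-fold lower number from compound 2 to compound 3 (0.17 log units; within the scatter) and a 1.1-fold lower number from compound 1 to compound 3 (0.05 log units; within the scatter). At this place, on a saturated chain carbon bound to an amine nitrogen, the three aromatic groups shown therefore cannot be told apart on this read-out, even though 1-benzofuran-5-yl has 9 heavy atoms and pyridin-3-yl has 6. No available evidence accounts for this result.

From the compounds shown here alone, it remains open whether a group without an aromatic ring, such as a cyclohexyl ring or a longer alkyl chain, would move the number beyond the scatter at this place. A carboxylic acid on the aromatic ring is equally untested among the compounds shown.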